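The source may hold more compounds than are shown below. What is called first, only, known or untested is meant among the compounds shown, and "the series" means these compounds.

Within the data shown here, in a functional assay on DU-145 cells (Homo sapiens) for cytotoxicity, read by sulforhodamine B assay, with a stated time of 48 h (a lower number here means a stronger inhibitor, a higher number a weaker inhibitor), three compounds with a shared core have numbers so far: compound 1 `C[C@H]1CC[C@@H]2[C@@H](OC(=O)[C@]23CC(c2ccc(N(C)C)cc2)=NO3)[C@]2(C)C(=O)C=C[C@@]12O` gives 4500 nM, compound 2 `C[C@H]1CC[C@@H]2[C@@H](OC(=O)[C@]23CC(c2cccc([N+](=O)[O-])c2)=NO3)[C@]2(C)C(=O)C=C[C@@]12O` gives 51000 nM, and compound 3 `Cc1ccc(C2=NO[C@]3(C2)C(=O)O[C@@H]2[C@H]3CC[C@H](C)[C@]3(O)C=CC(=O)[C@@]23C)cc1` gives 14000 nM, the second highest of the three. The next analogue, compound 4 `C[C@H]1CC[C@@H]2[C@@H](OC(=O)[C@]23CC(c2ccc(F)cc2)=NO3)[C@]2(C)C(=O)C=C[C@@]12O`, has fluoro in place of methyl on an aromatic carbon. The step that swaps the group at that position, a 3.1-fold higher number from compound 1 to compound 3 (0.49 log units; beyond the scatter), is modest, as is a 3.6-fold lower number from compound 2 to compound 3 (0.56 log units; beyond the scatter), whereas an 11-fold higher number from compound 1 to compound 2 (1.05 log units; beyond the scatter) is large. Among the measured compounds shown here, no measured compound carries fluoro, so only a small step of uncertain direction, possibly within the scatter, is expected. The expected change is a 1.1-fold lower number from compound 3 to compound 4 (0.03 log units; within the scatter). For compound 4 the estimated value is 13000 nM, within an expected range of 5000 nM to 35000 nM.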

Compound 4, half-maximal inhibitory concentration: 13000 nM
The estimate for compound 4 equals the measured number at the digits printed; measured number inside the range.
By their numbers in this assay, from the lowest: compound 1; then compounds 4 and 3 (each within the scatter of the next); then compound 2.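

At this position in this assay, fluoro and methyl cannot be told apart, with a 1.1-fold lower number from compound 3 to compound 4 (0.03 log units; within the scatter) between the 4-methylphenyl and 4-fluorophenyl analogues. Compound 4 therefore joins compound 3 in the middle of the series, with a 2.9-fold higher number from compound 1 to compound 4 (0.46 log units; beyond the scatter) on one side and a 3.9-fold lower number from compound 2 to compound 4 (0.59 log units; beyond the scatter) on the other. No measurement shown accounts for these steps. As far as these compounds go, it remains open whether the lower number of compound 1 is specific to dimethylamino or would also appear with a primary amine or methoxy. From the compounds shown here alone, how a carboxylic acid would read at this place is also open.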